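A few compounds are considered here, and "the series" means these few. Any claim that something is new, unique, unknown or untested is made for them only; others in the source may bear on it.

Compound 1, `CCOC(=O)[C@@H]1CCCN(S(=N)(=O)c2ccc(S(=O)(=O)N(CC)CC)cc2)C1`: in a functional assay on MIA PaCa-2 cells (Homo sapiens) for inhibition, read by MTT assay, with a stated time of 3 days (a higher number here means a weaker inhibitor, a lower number a stronger inhibitor), compound 1 gives > 10000 nM, which is a limit of the assay rather than a number.
Compound 2, `CCN(CC)S(=O)(=O)c1ccc(S(=O)(=O)N2CCC[C@@H](C(=O)N[C@@H]3CCN(C(=O)OC(C)(C)C)C3)C2)cc1`: in this assay compound 2 gives > 10000 nM, again only a limit.
Compound 3, `CCOC(=O)[C@@H]1CCCN(S(=O)(=O)c2ccc(S(=O)(=O)N3CCOCC3)cc2)C1`: in this assay compound 3 gives > 10000 nM, once more a limit.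

Compound 2 therefore stands at the edge of what the assay can report, and it is not alone there: all three measured results sit at the same limit, as the limit of > 10000 nM in this assay, at which 3 of the 3 values shown sit, records. Among the compounds with values here, no pair of measured compounds differs in just one place, so no measured step is available to size a change in potency.

Compound 4, `CCN1CC(NC(=O)[C@@H]2CCCN(S(=O)(=O)c3ccc(S(=O)(=O)N(CC)CC)cc3)C2)C1`, has not yet been measured. It differs from compound 2 in one place: 1-ethylazetidin-3-yl in place of 1-(tert-butoxycarbonyl)pyrrolidin-3-yl on an amide-type nitrogen. Within the data shown here, with every measured value resting at the limit, the expected step from compound 2 to compound 4 in this assay is none beyond the scatter, expressed as a step that the limit leaves unreadable from compound 2 to compound 4, since the limit of > 10000 nM in this assay, at which 3 of the 3 values shown sit, is the only guide. Compound 4 is thus expected to give about 12000 nM, estimated between 3000 nM and 50000 nM.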

Compound 4, half-maximal inhibitory concentration: > 10000 nM
Compound 4 was reported as a limit (the forecaster's own chance of this, stated with the estimate: 70%); the middle value is on the limit's open side.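

In this assay, within the data shown here, compound 2 and compound 4 each give only a limit rather than a number, so no step between them can be read. The compounds shown leave open how strong any of them really is, and which change to the shared core would give a readable value.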